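The compounds below may be only part of what the source reports. "The series", "measured", "known", "first", "only" and "open" are said of these compounds alone.

Compound 1 `CCc1ccc(-c2nn3cc(-c4cccc(N)c4)nc3s2)cc1`: 8200 nM
Compound 2 `C=C(Br)C(=O)Nc1cccc(-c2cn3nc(-c4ccc(CC)cc4)sc3n2)c1`: 3300 nM
Compound 3 `COc1cccc(Cc2nn3cc(-c4cccc(N)c4)nc3s2)c1`: 10000 nM

In a functional assay on FM3A cells (Mus musculus) for inhibition, read by cell counting, with a stated time of 2 days (a lower number here means a stronger inhibitor, a higher number a weaker inhibitor), compound 1 gives 8200 nM, the second highest of the three numbers. Compound 3 gives 10000 nM, which lies within the scatter of compound 1, while compound 2 gives 3300 nM. Going by the values given here, the only measured step runs a 2.5-fold lower number from compound 1 to compound 2 (0.40 log units; beyond the scatter), and it alters a nitrogen on an aromatic ring, not the place changed here. Compound 4 `Nc1cccc(-c2cn3nc(-c4ccccc4)sc3n2)c1` differs from compound 1 by hydrogen in place of ethyl on an aromatic carbon, on an aromatic carbon of a six-membered aromatic ring of carbon only, para to a large group. Among the compounds with values here, no measured step touches that place, so the size cannot be read from the data. The expected step is a 1.5-fold higher number from compound 1 to compound 4 (0.17 log units; within the scatter), probably within the scatter. Compound 4 is therefore estimated at 12000 nM, in a range from 4000 nM to 35000 nM.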

Compound 4, half-maximal inhibitory concentration: 14000 nM
Estimate against measurement, compound 4: 1.2-fold (0.07 log units) below, within the range that was stated.
By their numbers in this assay, from the lowest: compound 2; then compounds 1, 3 and 4 (each within the scatter of the next).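

In this assay, hydrogen in place of ethyl on the aromatic carbon para to a large group gives a 1.7-fold higher number from compound 1 to compound 4 (0.23 log units; within the scatter). Going by these compounds alone, this is the first reading at this position, and compound 1 and compound 4 cannot be told apart, so the ethyl is not needed to keep this level of inhibition. Nothing available gives a reason for this result.

From the compounds shown here alone, with only ethyl and hydrogen seen here, it remains open whether a longer chain such as butyl, a methoxy group or an amine would shift the number beyond the scatter. Going by these compounds, it is also open whether the (1-bromoethenyl)carbonyl group on the nitrogen would give a similar step on compound 4.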